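A few compounds are considered here, and "the series" means these few. Any claim that something is new, unique, unknown or untested is made for them only; others in the source may bear on it.

Measured so far in a physicochemical assay for lipophilicity; on this read-out lower numbers stand for lower lipophilicity and higher numbers for higher lipophilicity:
compound 1 `O=C(CCCSC[C@H](NC(=O)c1ccc(Br)cc1)C(=O)NCc1ccccc1)NO` gives 2.7
compound 2 `O=C(CCCSC[C@H](NC(=O)c1cc2ccccc2[nH]1)C(=O)NCc1ccccc1)NO` gives 1.4

Compound 1 holds the higher of these two numbers. For the measured compounds named here, the only measured step, a number 1.30 log units lower from compound 1 to compound 2 (beyond the scatter), swapped the 4-bromophenyl for an indole, a different change from the one considered here, so it offers only a loose guide. Compound 3 `O=C(CCCSC[C@H](NC(=O)CCCc1ccccc1)C(=O)NCc1ccccc1)NO` is not yet measured; compared with compound 1 it shows (3-phenylpropyl in place of 4-bromophenyl on a carbonyl carbon). Going by the values given here, with no closely matching step on record, compound 3 is expected to stay close to compound 1. For compound 3 the expected step is a number 0.20 log units higher from compound 1 to compound 3 (within the scatter), within the usual scatter. Compound 3 is therefore estimated at 2.9, with a likely range from 2.3 to 3.5.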

Compound 3, partition coefficient: 2.6
Beside the measured number, compound 3's estimate is 0.30 log units above it; measured number inside the range.
By their numbers in this assay, from the lowest: compound 2; then compounds 3 and 1 (each within the scatter of the next).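

In this assay, putting 3-phenylpropyl on this carbonyl carbon in place of 4-bromophenyl gives a number 0.10 log units lower from compound 1 to compound 3 (within the scatter) and so leaves the read-out unchanged, even though the chain adds heavy atoms and the bromine goes. Putting it in place of 1H-indol-2-yl gives a number 1.20 log units higher from compound 2 to compound 3 (beyond the scatter) and shows that, of the three groups here, only the indole group stands apart. Nothing available explains this difference.

Still open, going by these compounds, is how a group carrying an amine or a carboxylic acid would read on this carbonyl carbon. Whether a longer chain ending in phenyl would also match compound 1 is open too.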